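The source may report more compounds than this note shows. Statements on the series, on what has been measured and on what is new or still open speak of the compounds shown alone.

In a functional assay on KB403 cells (Homo sapiens) for cytotoxicity, read by MTT assay, with stated times of 6 h and 48 h (on this read-out lower numbers stand for stronger inhibition and higher numbers for weaker inhibition), compound 2 `Cn1c(/C=C/C(=O)c2ccccc2)cc(Br)c1Br` gives >= 100000 nM, a limit and not a number. Compound 3 `Cn1c(/C=C/C(=O)c2ccc(O)cc2)cc(Br)c1Br` gives >= 100000 nM, also a limit. Together these two make up (the limit of >= 100000 nM in this assay, at which 2 of the 3 values shown sit). Among the compounds with values here, compound 1 `Cn1c(/C=C/C(=O)c2ccccc2O)cc(Br)c1Br` gives 8320 nM, the only actual number so far. Compound 4 `Cn1c(/C=C/C(=O)c2cccc(N)c2)cc(Br)c1Br` differs from compound 2 by amino in place of hydrogen on an aromatic carbon, with amino in place of hydrogen on an aromatic carbon. Within the data shown here, two measured steps bear on this, both hydroxy exchanges rather than amino ones. The first, an at least 12-fold higher number from compound 1 to compound 2 (1.07 log units; beyond the scatter), is large, while the second, a step that the two limits leave unreadable from compound 2 to compound 3, cannot be read. Only a modest move toward a lower number is therefore expected in this assay, and another limit is quite possible. The estimated step is an at least 2.0-fold lower number from compound 2 to compound 4 (0.30 log units; that floor lies within the scatter). Compound 4 is estimated at 50000 nM, with an expected range of 12000 nM to 150000 nM.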

Compound 4, half-maximal inhibitory concentration: >= 100000 nM
Compound 4 ended at the assay's limit; the forecaster's own chance of this, stated with the estimate: 55%; middle value at least 2.0-fold (0.30 log units) away from the limit.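

Compound 2 and compound 4 both end at a limit in this assay, so the step between them cannot be read: the limit of >= 100000 nM in this assay, at which 3 of the 4 values shown sit.

The compounds shown leave open whether amino in place of hydrogen on an aromatic carbon shifts the read-out at all.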